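A few compounds are considered here, and "the series" means these few. Any claim that something is new, unique, unknown or untested is made for them only; others in the source may bear on it.

Compound 1 `CNC(=O)c1cc(Oc2ccc3nc(NC(=O)Nc4cc(C(F)(F)F)cc(C(F)(F)F)c4)sc3c2)ccn1` and compound 2 `CNC(=O)c1cc(Oc2ccc3nc(NC(=O)c4ccc(Cl)cc4Cl)sc3c2)ccn1` share one core and were both tested in a functional assay on SK-BR-3 cells (Homo sapiens) for inhibition, read by MTT assay, with a stated time of 2 days, tested at 100 uM; a higher number here means more inhibition of growth at the concentration tested, a lower number less inhibition of growth. There compound 1 gives 96.3%, while compound 2 gives 81%, the lower of the two numbers, with compound 1 above it by more than the usual scatter. Going by these compounds, compound 3 `CNC(=O)c1cc(Oc2ccc3nc(NC(=O)c4ccc(Cl)cc4)sc3c2)ccn1` is untested. It differs from compound 2 in one place: hydrogen in place of chloro on an aromatic carbon, a hydrogen in place of chloro on an aromatic carbon. Among the measured compounds shown here, no measured pair shows this kind of change, so the step in this assay is expected to be small and at most modestly downward, estimated as a number 7 percentage points lower from compound 2 to compound 3 (within the scatter). Compound 3 is estimated at 74%, within 52% to 92%.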

Compound 3, percent growth inhibition at one concentration: 83%
Compound 3: middle estimate off by 9 percentage points, on the low side, within the range that was stated.
By their numbers in this assay, from the lowest: compounds 2 and 3 (each within the scatter of the next); then compound 1.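

In this assay, among the compounds shown here, hydrogen in place of chloro on the aromatic carbon ortho to a large group gives a number 2 percentage points higher from compound 2 to compound 3 (within the scatter), the first reading of this change. At this position, then, the 2,4-dichlorophenyl and 4-chlorophenyl versions cannot be told apart at the single concentration tested. Nothing available explains this result. Still open, going by these compounds, is how other groups at this position, such as an amine, a carboxylic acid or a longer chain, would read. On these data alone, the effect of replacing the remaining chloro group also remains open.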